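Trimethoxyphenyl in Place of Nitrophenyl: Expected Cell Tolerance

A few compounds are considered here, and "the series" means these few. Any claim that something is new, unique, unknown or untested is made for them only; others in the source may bear on it.

Compound 1 `CSc1nc(NCCCNc2ccnc3cc(Cl)ccc23)c(C#N)c(-c2ccccc2)n1` and compound 2 `CSc1nc(NCCCCNc2ccnc3cc(Cl)ccc23)c(C#N)c(-c2cccc([N+](=O)[O-])c2)n1` belong to one series. In an ADME assay on MDCK cells (Canis lupus familiaris) for cytotoxicity, read by microscopy (a lower number here means that less compound is tolerated, a higher number that more compound is tolerated), compound 1 gives 20000 nM. Compound 2 gives 20000 nM in this assay, level with compound 1 within the scatter, so compound 2 stands where compound 1 stands. Compound 3 `CSc1nc(-c2ccc([N+](=O)[O-])cc2)c(C#N)c(N2CCN(c3ccnc4cc(Cl)ccc34)CC2)n1` reaches only a limit of the assay in this assay, reported as > 100000 nM. Compound 4 `COc1cc(-c2nc(SC)nc(NCCCCNc3ccnc4cc(Cl)ccc34)c2C#N)cc(OC)c1OC` awaits measurement; it differs from compound 2 by 3,4,5-trimethoxyphenyl in place of 3-nitrophenyl on an aromatic carbon. Among the measured compounds shown here, no step between measured compounds mirrors this exchange, so the data give no direction for it. The step from compound 2 to compound 4 is therefore expected to be none beyond the scatter, no change at the digits printed from compound 2 to compound 4 (within the scatter). In this assay compound 4 is estimated at 20000 nM, within 10000 nM to 50000 nM.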

Compound 4, minimum cytotoxic concentration: 4000 nM
For compound 4 the middle estimate is 5.0-fold (0.70 log units) above the measured one; the whole stated range lies above it.
By their numbers in this assay, from the lowest: compound 4; then compounds 1 and 2 (each within the scatter of the next). At a limit, above all of these: compound 3.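

In this assay, 3,4,5-trimethoxyphenyl in place of 3-nitrophenyl gives a 5.0-fold lower number from compound 2 to compound 4 (0.70 log units; beyond the scatter), so the group at this position on the shared core can change how much compound the cells tolerate. The earlier compounds shown here offered no step at this position, and this one points toward less compound being tolerated. Nothing measured here accounts for the change.

From the compounds shown here alone, it remains open whether one methoxy group on the phenyl ring would give the same result as three. Going by these compounds, how an aminophenyl or a carboxyphenyl group would read at this position also remains open.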